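Sulfonyl Aryl Swaps on a Shared Quinoline-Type Core

This account rests on a few compounds, and the source may have more. Where it says the series, first, only, none or still open, it means among the compounds named here.

The measured compounds are:
compound 1, `Cc1ccc(S(=O)(=O)c2cnc3ccc(Cl)cc3c2N2CCC(C)CC2)cc1C`, 84% in an assay on isolated protein for displacement of a labelled ligand from metabotropic glutamate receptor 5 (Homo sapiens), with a stated time of 60 min, tested at 1 uM; a higher number here means more inhibition at the concentration tested (going by the name of the read-out), a lower number less inhibition;
compound 2, `Cc1ccc(S(=O)(=O)c2cnc3ccc(Cl)cc3c2N2CCC(C)CC2)cc1F`, 68%;
compound 3, `COc1ccc(S(=O)(=O)c2cnc3ccc(Cl)cc3c2N2CCC(C)CC2)cc1OC`, 61%.

Compound 3 gives the lowest of the three numbers. Its nearest neighbour is compound 2, whose value lies within the scatter, as the step of a number 7 percentage points lower from compound 2 to compound 3 (within the scatter) shows; the furthest is compound 1, and the step of a number 23 percentage points lower from compound 1 to compound 3 (beyond the scatter) lies beyond the scatter. The step of a number 16 percentage points lower from compound 1 to compound 2 (beyond the scatter) is also beyond the scatter.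

Compound 4, `CC1CCN(c2c(S(=O)(=O)c3cc(F)cc(F)c3)cnc3ccc(Cl)cc23)CC1`, is not yet measured. It differs from compound 3 as follows: 3,5-difluorophenyl in place of 3,4-dimethoxyphenyl on a sulfonyl sulfur. Among the compounds with values here, the steps that bear on the group attached to the sulfonyl sulfur are the three above. Compound 2, which carries one fluorine on that ring, sits within the scatter of compound 3, so no step beyond the scatter is expected here. Compound 4 is estimated at 62%, between 42% and 80%, which is an expected step of a number 1 percentage points higher from compound 3 to compound 4 (within the scatter).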

Compound 4, a percentage reported as inhibition, at one concentration (the size of the read-out at that concentration, not a potency): 93%
Estimate against measurement, compound 4: 31 percentage points below; measured number outside the range, above it.
By their numbers in this assay, from the lowest: compounds 3 and 2 (each within the scatter of the next); then compounds 1 and 4 (each within the scatter of the next).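

Within the data shown here, the aryl group on the sulfonyl sulfur can swing the read-out further than the earlier compounds showed: in this assay the change to 3,5-difluorophenyl gives a number 32 percentage points higher from compound 3 to compound 4 (beyond the scatter) and a number 25 percentage points higher from compound 2 to compound 4 (beyond the scatter) on the way to a value level with the 3,4-dimethylphenyl group. Fluorine on this ring does not in itself go with a lower number, as the single fluorine of compound 2 sits with 68% in the lower pair while the two of compound 4 do not, and a number 9 percentage points higher from compound 1 to compound 4 (within the scatter) puts compound 4 alongside compound 1. Nothing available explains why these aryl groups differ.

From the compounds shown here alone, it remains open whether the number of fluorines or their placement matters, and how 3,5-dichlorophenyl, 3,5-dimethylphenyl or pyridyl would compare on the sulfonyl sulfur. Going by these compounds, whether the change holds with a different amine on the shared core is also open.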